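The source may report more compounds than this note shows. Statements on the series, on what has been measured and on what is new or still open speak of the compounds shown alone.

Measured compounds:
- compound 1, `COc1ccc(CN(C(=O)CCl)c2cc(OC)c(OC)c(OC)c2)cc1O`: 210 nM
- compound 2, `C/C=C/C(=O)N(Cc1ccc(OC)c(Cl)c1)c1cc(OC)c(OC)c(OC)c1`: 10100 nM
- compound 3, `C/C=C/C(=O)N(Cc1ccc(OC)c(OC)c1)c1cc(OC)c(OC)c(OC)c1`: 39100 nM

In a functional assay on KYSE-450 cells (Homo sapiens) for inhibition, read by MTT assay, with a stated time of 48 h (a lower number here means a stronger inhibitor, a higher number a weaker inhibitor), compound 1 gives the lowest of the three numbers; compound 2 and compound 3 sit well above it, and since each of them differs from compound 1 in more than one place, only their values can be set beside it. Among the measured compounds shown here, the one step measured within a single change, a 3.9-fold higher number from compound 2 to compound 3 (0.59 log units; beyond the scatter), concerns the benzyl ring and not the chain bound to the carbonyl.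

Compound 4, `CCCCC(=O)N(Cc1ccc(OC)c(O)c1)c1cc(OC)c(OC)c(OC)c1`, differs from compound 1 as follows: propyl in place of chloro on a saturated chain carbon bound to a carbonyl carbon. For the measured compounds named here, no measured pair shows what this change does; the step from compound 2 to compound 3 does not touch the chain, so it gives no guide. The expectation therefore rests on the position of compound 1 alone, with the change treated as one that may cost activity. Compound 4 is estimated to give 2500 nM in this assay, within 400 nM to 20000 nM, which is expected to be a step of a 12-fold higher number from compound 1 to compound 4 (1.08 log units; beyond the scatter) and is highly uncertain.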

Compound 4, half-maximal inhibitory concentration: 300 nM
Compound 4: middle estimate off by 8.3-fold (0.92 log units), on the high side, and the stated range ends above it.
By their numbers in this assay, from the lowest: compounds 1 and 4 (each within the scatter of the next); then compound 2; then compound 3.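

In this assay the exchange at this position stays within the scatter, with a 1.4-fold higher number from compound 1 to compound 4 (0.15 log units; within the scatter). Propyl in place of chloro on a saturated chain carbon bound to a carbonyl carbon therefore leaves the number where it was, so within this pair the chloro is not needed for a value in this range. The earlier compounds shown here could not show this, since compound 2 and compound 3 each differ from compound 1 in more than one place. Nothing measured here accounts for this result.

The compounds shown leave open whether a longer chain, an amine or a carboxylic acid in place of the propyl would keep the value. They also leave open what the hydroxy group on the benzyl ring of compound 1 and compound 4 contributes.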